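A few compounds are considered here, and "the series" means these few. Any claim that something is new, unique, unknown or untested is made for them only; others in the source may bear on it.

Compound 3 `Cc1cc(C)cc(-n2nncc2CN2C(=O)C3(C(C#N)=C(N)Oc4c(N)cc5nc6ccccc6nc5c43)c3ccccc32)c1` is one of three measured members of a series that share a common core and differ only in the aryl group on the aromatic nitrogen of the triazole. In a functional assay on HepG2 cells (Homo sapiens) for antiproliferative activity, read by MTT assay, with a stated time of 48 h (on this read-out lower numbers stand for stronger inhibition and higher numbers for weaker inhibition), compound 1 `CCc1ccccc1-n1nncc1CN1C(=O)C2(C(C#N)=C(N)Oc3c(N)cc4nc5ccccc5nc4c32)c2ccccc21` gives 17900 nM. For compound 2 `COc1ccccc1-n1nncc1CN1C(=O)C2(C(C#N)=C(N)Oc3c(N)cc4nc5ccccc5nc4c32)c2ccccc21` this assay reports only a limit, > 50000 nM. For compound 3 this assay likewise reports only a limit, > 50000 nM. Among the values shown, compound 3 therefore stands at the weak end, sitting at the limit of > 50000 nM in this assay, at which 2 of the 3 values shown sit, together with compound 2.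

Compound 4 `N#CC1=C(N)Oc2c(N)cc3nc4ccccc4nc3c2C12C(=O)N(Cc1cnnn1-c1ccc([N+](=O)[O-])cc1[N+](=O)[O-])c1ccccc12` is not yet measured. It differs from compound 3 by 2,4-dinitrophenyl in place of 3,5-dimethylphenyl on an aromatic nitrogen.

The measured steps that bear on this position are an at least 2.7-fold higher number from compound 1 to compound 3 (0.44 log units; beyond the scatter) and a step that the two limits leave unreadable from compound 2 to compound 3; the step of an at least 2.7-fold higher number from compound 1 to compound 2 (0.44 log units; beyond the scatter) changes a group on an aromatic carbon within the aryl ring. None of these steps involves a nitro-bearing ring, so they give no direction for the change to compound 4 beyond showing that compound 3 already rests at the limit. Compound 4 is therefore expected to remain near that limit, with the step of a number no higher from compound 3 to compound 4 (the limit leaves the size open) most likely within the scatter. The estimate for compound 4 in this assay is 50000 nM, with a range from 15000 nM to 200000 nM.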

Compound 4, half-maximal inhibitory concentration: 18400 nM
Compound 4: the middle estimate sits 2.7-fold (0.43 log units) above what was measured; the measured number falls inside the stated range.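

In this assay, the 2,4-dinitrophenyl group on the aromatic nitrogen gives a readable value where the 3,5-dimethylphenyl and 2-methoxyphenyl groups do not, with an at least 2.7-fold lower number from compound 3 to compound 4 (0.43 log units; beyond the scatter) and an at least 2.7-fold lower number from compound 2 to compound 4 (0.43 log units; beyond the scatter). Until now only the 2-ethylphenyl group had given a readable value at this position, and the comparison with that group yields a 1.0-fold higher number from compound 1 to compound 4 (0.01 log units; within the scatter), so the two rings cannot be told apart in this assay although they carry quite different substituents. Compound 2 and compound 3 remain at a limit of the assay rather than at a number: the limit of > 50000 nM in this assay, at which 2 of the 4 values shown sit.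

The compounds shown do not separate the two nitro groups, so it remains open whether one of them alone would give the same value, and the true size of the steps from the two limits also remains unknown. Going by these compounds, it is equally open how the value would respond to an amine or a carboxylic acid on this aryl ring, or to a longer chain in place of the ethyl group of compound 1.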